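The compounds below may be only part of what the source reports. "The series", "measured", "known", "first", "only" and "open" are said of these compounds alone.

Measured so far:
Compound 1, `CC(=O)N1CCN(C(=O)N2Cc3c(NC(=O)c4ccc(F)cc4)n[nH]c3C2(C)C)CC1`: in a physicochemical assay for solubility, at pH 7 (on this read-out lower numbers stand for lower solubility and higher numbers for higher solubility), compound 1 gives > 225000 nM, a limit of the assay rather than a number.
Compound 2, `CN1CCC(C(=O)N2Cc3c(NC(=O)c4cc(F)cc(F)c4)n[nH]c3C2(C)C)CC1`: in this assay compound 2 gives > 225000 nM, again a limit.
Compound 3, `CC(C)CC(=O)Nc1n[nH]c2c1CN(C(=O)C1CCN(C3CC3)CC1)C2(C)C`: in this assay compound 3 gives > 225000 nM, again a limit.

Compound 2 therefore stands at the limit, and the two further values shown sit there too, (the limit of > 225000 nM in this assay, at which 3 of the 3 values shown sit). For the measured compounds named here, no step between measured compounds is available, so nothing measured fixes the size of the change leading to compound 4, `CN1CCC(C(=O)N2Cc3c(NC(=O)c4cccc(F)c4)n[nH]c3C2(C)C)CC1`. The change is hydrogen in place of fluoro on an aromatic carbon. Given (the limit of > 225000 nM in this assay, at which 3 of the 3 values shown sit), no move beyond the scatter is expected in either direction, and a reading at the limit again is the likely outcome. The step expected is a step that the limit leaves unreadable from compound 2 to compound 4. For compound 4 the estimate in this assay is 300000 nM, within 150000 nM to 900000 nM.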

Compound 4, solubility: > 225000 nM
Compound 4: no number, only a limit (the forecaster's own chance of this, stated with the estimate: 85%); the middle value lies beyond the limit too.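

Compound 2 and compound 4 both give only limits in this assay, so no step between them can be read: the limit of > 225000 nM in this assay, at which 4 of the 4 values shown sit.

The compounds shown leave open whether hydrogen in place of fluoro on this aromatic carbon shifts the read-out at all.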